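A few compounds are considered here, and "the series" means these few. Any claim that something is new, unique, unknown or untested is made for them only; others in the source may bear on it.

Measured in an assay on isolated protein for inhibition of ceramide glucosyltransferase (Homo sapiens); on this read-out lower numbers stand for stronger inhibition and higher numbers for weaker inhibition:
compound 1 `N#Cc1ccc(-c2ccc(COCCCCCN3C[C@H](O)[C@@H](O)[C@H](O)[C@H]3CO)cc2)cc1`, 150 nM
compound 2 `OC[C@@H]1[C@@H](O)[C@H](O)[C@@H](O)CN1CCCCCOCc1ccc(-c2ccccc2F)cc1`, 75 nM
compound 3 `OC[C@@H]1[C@@H](O)[C@H](O)[C@@H](O)CN1CCCCCOCc1ccc(-c2ccc(C(F)(F)F)cc2)cc1`, 20 nM

Compound 3 stands at the lowest number of the three; compound 2 is nearest to it and compound 1 furthest, both steps beyond the scatter. Compound 4 `OC[C@@H]1[C@@H](O)[C@H](O)[C@@H](O)CN1CCCCCOCc1ccc(-c2ccc(F)nc2)cc1` differs from compound 3 by 6-fluoropyridin-3-yl in place of 4-(trifluoromethyl)phenyl on an aromatic carbon. For the measured compounds named here, two measured steps bear on this: a 7.5-fold lower number from compound 1 to compound 3 (0.88 log units; beyond the scatter) and a 3.8-fold lower number from compound 2 to compound 3 (0.57 log units; beyond the scatter), both arriving at compound 3 by introducing the trifluoromethyl group. Going by the values given here, compound 4 gives that group up and brings in a ring with one hetero atom and one hydrogen-bond acceptor, for which no measured step exists. The loss of the trifluoromethyl alone points to a modestly higher number in this assay. Compound 4 is therefore expected near 70 nM, within 30 nM to 180 nM. The expected step is a 3.5-fold higher number from compound 3 to compound 4 (0.54 log units; beyond the scatter).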

Compound 4, half-maximal inhibitory concentration: 750 nM
Compound 4: the middle estimate sits 11-fold (1.03 log units) below what was measured; measured number above the stated range.
By their numbers in this assay, from the lowest: compound 3; then compounds 2 and 1 (each within the scatter of the next); then compound 4.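

6-Fluoropyridin-3-yl is the first group at this aromatic position to stand clearly apart from all the others, with a 38-fold higher number from compound 3 to compound 4 (1.57 log units; beyond the scatter), a 10-fold higher number from compound 2 to compound 4 (1.00 log units; beyond the scatter) and a 5.0-fold higher number from compound 1 to compound 4 (0.70 log units; beyond the scatter). The position therefore spans a much wider range than the first three compounds showed, and compound 4 falls behind even compound 1, the weakest of those three. Nothing available accounts for the size of this loss.

As far as these compounds go, whether it follows from the ring nitrogen or from the exchange of trifluoromethyl for fluorine stays open. A fluorophenyl group and a trifluoromethyl-substituted pyridine ring at this position would separate the two.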